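Replacing diethylamino with piperazin-1-yl

The source may hold more compounds than are shown below. What is called first, only, known or untested is meant among the compounds shown, and "the series" means these compounds.

Measured in a functional assay on NCI-H460 cells (Homo sapiens) for inhibition, read by sulforhodamine B assay, with a stated time of 72 h; a lower number here means a stronger inhibitor, a higher number a weaker inhibitor:
compound 1 `CCNC(=O)c1nnn(-c2cc(C(C)C)c(O)cc2O)c1-c1ccc(CN2CCCC(O)C2)cc1` gives 62 nM
compound 2 `CCNC(=O)c1nnn(-c2cc(C(C)C)c(O)cc2O)c1-c1ccc(CN2CCCC2)cc1` gives 3 nM
compound 3 `CCNC(=O)c1nnn(-c2cc(C(C)C)c(O)cc2O)c1-c1ccc(CN(CC)CC)cc1` gives 11 nM

Compound 3, at 11 nM as the second highest of the three numbers, sits in the middle. Unmeasured compound 4 `CCNC(=O)c1nnn(-c2cc(C(C)C)c(O)cc2O)c1-c1ccc(CN2CCNCC2)cc1` differs from it by piperazin-1-yl in place of diethylamino on a saturated chain carbon bound to an aromatic carbon on the same carbon. Three steps at this place bear on the change: a 5.6-fold lower number from compound 1 to compound 3 (0.75 log units; beyond the scatter) and a 3.7-fold higher number from compound 2 to compound 3 (0.56 log units; beyond the scatter) are modest, while a 21-fold lower number from compound 1 to compound 2 (1.32 log units; beyond the scatter) is large. Compound 1, whose 3-hydroxypiperidin-1-yl is also a six-membered non-aromatic ring, gives 62 nM and is the closest guide. A modest rise in this assay is therefore expected. The expected change is a 2.7-fold higher number from compound 3 to compound 4 (0.44 log units; beyond the scatter) in this estimate. For compound 4 the estimated value is 30 nM with an expected range of 9 nM to 100 nM overall.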

Compound 4, half-maximal inhibitory concentration: 250 nM
Compound 4: the middle estimate sits 8.3-fold (0.92 log units) below what was measured, outside the stated range (above it).
By their numbers in this assay, from the lowest: compound 2; then compound 3; then compound 1; then compound 4.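

In this assay compound 4 is the weakest of the four, with a 23-fold higher number from compound 3 to compound 4 (1.36 log units; beyond the scatter) and an 83-fold higher number from compound 2 to compound 4 (1.92 log units; beyond the scatter) and a 4.0-fold higher number from compound 1 to compound 4 (0.61 log units; beyond the scatter) in the same direction. A six-membered non-aromatic ring at this place therefore does not by itself match 3-hydroxypiperidin-1-yl, and the two groups with a second hetero atom now give the two highest numbers. No measurement shown accounts for this rise. Still open, on these data alone, is whether the rise follows the second ring nitrogen or its hydrogen, which morpholin-4-yl and 4-methylpiperazin-1-yl at this place could separate.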